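The source may report more compounds than this note shows. Statements on the series, on what has been measured and on what is new or still open speak of the compounds shown alone.

The study rests on two measured compounds and one that still awaits its number. Among the compounds with values here, compound 1 `C#CCOc1ccc(/C=C/C(=O)c2cccc(Br)c2)cc1OC` is the only compound with a read value in a functional assay on CCRF-CEM cells (Homo sapiens) for cytotoxicity, with a stated time of 72 h; a higher number here means a weaker inhibitor, a lower number a stronger inhibitor: in this assay compound 1 gives 15200 nM. Compound 2 `C#CCOc1ccc(C(=O)/C=C/c2ccc(OCC=C)c(OC)c2)cc1CC=C` does not yield a number; in this assay compound 2 returns > 50000 nM, which is a limit of the assay and not a measured value. Of the two values shown, one sits at the limit of > 50000 nM in this assay, at which 1 of the 2 values shown sits. Within the data shown here, compound 1 therefore stands as the single fixed point on the scale, with no measured step to any neighbour.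

Compound 3 `C#CCOc1ccc(/C=C/C(=O)c2ccccc2C)cc1OC` differs from compound 1 in one place (2-methylphenyl in place of 3-bromophenyl on a carbonyl carbon). Among the measured compounds shown here, no step between measured compounds resembles this change, so the size of the step in this assay can only be expected rather than read. Nothing in the two measurements points to a marked gain, and compound 3 is expected to stay close to compound 1, the estimated step from compound 1 to compound 3 being a 1.3-fold higher number from compound 1 to compound 3 (0.12 log units; within the scatter), within the usual scatter or slightly toward the weaker side. The estimate for compound 3 in this assay is 20000 nM, with a range from 7000 nM to 50000 nM.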

Compound 3, half-maximal inhibitory concentration: 6950 nM
Beside the measured number, compound 3's estimate is 2.9-fold (0.46 log units) above it; the whole stated range lies above it.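

In this assay, within the data shown here, the group on the carbonyl carbon now has a measured effect: 2-methylphenyl in place of 3-bromophenyl gives a 2.2-fold lower number from compound 1 to compound 3 (0.34 log units; beyond the scatter), the first step that can be read, and it runs toward the stronger side. The change also shows that this place on the shared core tolerates the loss of the bromine without any loss of activity, at least for this one replacement. The two groups match in heavy atoms, in their aromatic ring, in hydrogen-bond donors and acceptors and in charge, and nothing measured here gives a property that would account for the step.

From the compounds shown here alone, a single exchange alters both the kind of substituent and where it sits on the ring, so it remains open whether the methyl group itself or its placement carries the step. Going by these compounds, how a plain phenyl, or a phenyl bearing an amine or a carboxylic acid, on the same carbonyl carbon would read in this assay also remains open, and so does whether any such group would take the number further down.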